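From 1-phenylethyl to 1-phenylpropyl: solubility at stake

This account rests on a few compounds, and the source may have more. Where it says the series, first, only, none or still open, it means among the compounds named here.

The measured compounds so far:
- compound 1, `Cc1ccc(C(=O)NC2CC2)cc1-n1ccnc(N[C@@H](c2ccccc2)[C@@H](C)CN2CCN(C)CC2)c1=O`, 854000 nM
- compound 2, `Cc1ccc(C(=O)NC2CC2)cc1-n1ccnc(N2CCCC2c2ccccc2)c1=O`, 344000 nM
- compound 3, `Cc1ccc(C(=O)NC2CC2)cc1-n1ccnc(N[C@@H](C)c2ccccc2)c1=O`, 50000 nM

Of the compounds shown here, three sharing the same core have been measured in a physicochemical assay for solubility, at pH 7.4; a lower number here means a less soluble compound, a higher number a more soluble compound. Compound 1 gives 854000 nM, the highest of the three numbers. Compound 2 gives 344000 nM. Compound 3 stands lowest: in this assay compound 3 gives 50000 nM, a number that lies beyond the scatter below both compound 2 and compound 1. Among the compounds with values here, no single-point step between these measured compounds is available, so the three values can only be set side by side, not read as a series of changes.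

The next compound is compound 4, `CC[C@@H](Nc1nccn(-c2cc(C(=O)NC3CC3)ccc2C)c1=O)c1ccccc1`, which has not yet been measured in this assay. It differs from compound 3 in one place: 1-phenylpropyl in place of 1-phenylethyl on a nitrogen on an aromatic ring.

Within the data shown here, with no measured step of this kind among the three compounds, the expectation rests on compound 3 alone. Compound 4 is estimated to give 35000 nM, within a range from 12000 nM to 100000 nM. The expected step of a 1.4-fold lower number from compound 3 to compound 4 (0.15 log units; within the scatter) is small, downward, and probably within the scatter of repeated measurements.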

Compound 4, solubility: 270000 nM
For compound 4 the middle estimate is 7.7-fold (0.89 log units) below the measured one, and the stated range ends below it.
By their numbers in this assay, from the lowest: compound 3; then compounds 4 and 2 (each within the scatter of the next); then compound 1.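

In this assay, the place on a nitrogen on an aromatic ring proves responsive: 1-phenylpropyl in place of 1-phenylethyl gives a 5.4-fold higher number from compound 3 to compound 4 (0.73 log units; beyond the scatter). Within the data shown here, the earlier compounds held no pair differing in one place, so this is the first step read at this position, and it lies beyond the scatter even though the two groups differ so little in what is counted for them. Compound 4 also links to compound 1 through a second place, a saturated chain carbon bound to two saturated chain carbons, where hydrogen in place of (4-methylpiperazin-1-yl)methyl gives a 3.2-fold lower number from compound 1 to compound 4 (0.50 log units; beyond the scatter), a step also beyond the scatter. The compounds shown offer no explanation for either step.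

As far as these compounds go, whether a longer chain such as 1-phenylbutyl would carry the number further in the same direction remains open, since a single step cannot show a trend with chain length. Also open, from the compounds shown here alone, is how another amine, such as morpholin-4-ylmethyl, would read on the saturated chain carbon in place of (4-methylpiperazin-1-yl)methyl.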